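From fluoro to hydroxy on compound 2

This account rests on a few compounds, and the source may have more. Where it says the series, first, only, none or still open, it means among the compounds named here.

Measured in an ADME assay on HEK293 cells (Homo sapiens) for cytotoxicity, with a stated time of 72 h; a higher number here means that more compound is needed for the effect, a lower number that less compound is needed:
- Compound 1 `O=C(Nc1ccc(F)c(-c2nc3ccccc3o2)c1)c1cc([N+](=O)[O-])ccc1Cl`: > 25000 nM (a limit)
- Compound 2 `O=C(Nc1ccc(F)c(-c2nc3ccccc3s2)c1)c1cc([N+](=O)[O-])ccc1Cl`: > 25000 nM (a limit)

Neither measured compound has an exact value. Compound 2 gives > 25000 nM, which is a limit and not a number. The picture so far is simple: the limit of > 25000 nM in this assay, at which 2 of the 2 values shown sit.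

Within the data shown here, the only measured step is a step that the two limits leave unreadable from compound 1 to compound 2. It gives no size to carry forward.

Compound 3 `O=C(Nc1ccc(O)c(-c2nc3ccccc3s2)c1)c1cc([N+](=O)[O-])ccc1Cl` differs from compound 2 in one group: hydroxy in place of fluoro on an aromatic carbon. The hydroxy takes the place of fluoro on an aromatic carbon, ortho to a 1,3-benzothiazol-2-yl group and para to a large group. Among the measured compounds shown here, no measured step covers this exchange, so the data give neither a size nor a direction for it. No step beyond the scatter is expected in this assay, and another limit is the most likely report. The expected change is a number no higher from compound 2 to compound 3 (the limit leaves the size open). Compound 3 is estimated at 25000 nM, with an expected range from 10000 nM to 40000 nM.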

Compound 3, half-maximal effective concentration: > 25000 nM
Compound 3 ended at the assay's limit (the forecaster's own chance of this, stated with the estimate: 70%); the middle value sits exactly at the limit.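

In this assay compound 3 gives > 25000 nM, which is a limit. No step from compound 2 to compound 3 can therefore be read, and the result so far is a single one: the limit of > 25000 nM in this assay, at which 3 of the 3 values shown sit.

The compounds shown leave open how much of any of them is needed for the effect, and so whether either exchange alters that amount.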